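This account rests on a few compounds, and the source may have more. Where it says the series, first, only, none or still open, it means among the compounds named here.

Measured so far in an in vitro functional assay on RBL cells for antagonist activity at C-C chemokine receptor type 8 (Homo sapiens), read by FLIPR and calcium flux; on this read-out lower numbers stand for stronger inhibition and higher numbers for weaker inhibition:
compound 1 `COc1ccc2nccc(C3CN(C4CCN(Cc5ccc6ccccc6c5)CC4)C(=O)O3)c2c1`: 1260 nM
compound 2 `COc1ccc2nccc(C3CN(C4CCN(CC5CCCCC5)CC4)C(=O)O3)c2c1`: 7940 nM
compound 3 `COc1ccc2nccc(C3CN(C4CCN(Cc5ccccc5)CC4)C(=O)O3)c2c1`: 12600 nM

Compound 3 gives the highest number of the three; compound 2 sits within the scatter of it, while compound 1 is set apart by a 10-fold higher number from compound 1 to compound 3 (1.00 log units; beyond the scatter). Compound 4 `COc1ccc2nccc(C3CN(C4CCN(S(=O)(=O)c5ccc(Cl)c(Cl)c5)CC4)C(=O)O3)c2c1` carries (3,4-dichlorophenyl)sulfonyl in place of benzyl on an amine nitrogen in a ring. Going by the values given here, the steps that touch this position are a 10-fold higher number from compound 1 to compound 3 (1.00 log units; beyond the scatter) and a 1.6-fold higher number from compound 2 to compound 3 (0.20 log units; within the scatter); both swap one ring on the same saturated linking carbon for another, and none replaces that linking carbon itself, so no measured step covers a sulfonyl link. Among the compounds with values here, the one larger group tried, in compound 1, brought the lower number. The expected change is a 2.5-fold lower number from compound 3 to compound 4 (0.40 log units; beyond the scatter), with wide uncertainty. Compound 4 is expected at 5000 nM, from 1000 nM to 25000 nM.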

Compound 4, half-maximal inhibitory concentration: < 50200 nM
Compound 4: only a limit was reported; the forecaster's own chance of this, stated with the estimate: 15%; the middle value does not contradict the limit.
By their numbers in this assay, from the lowest: compound 1; then compounds 2 and 3 (each within the scatter of the next).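

In this assay compound 4 has only a limit, < 50200 nM, and its steps from compound 1, compound 2 and compound 3 cannot be read. Going by these compounds, what stays open is how (3,4-dichlorophenyl)sulfonyl compares with benzyl, cyclohexylmethyl or (naphthalen-2-yl)methyl on the ring amine nitrogen.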